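Glycolamide to dimethylamino chain: expected antiproliferative shift

The compounds below may be only part of what the source reports. "The series", "measured", "known", "first", "only" and "open" are said of these compounds alone.

Measured in a functional assay on MCF7 cells (Homo sapiens) for antiproliferative activity, read by MTT assay, with a stated time of 48 h; a higher number here means a weaker inhibitor, a lower number a stronger inhibitor
- compound 1 `COc1ccc(C(=O)c2ccc3c(c2)C=CC(C)(C)O3)c(NC(=O)CO)c1` gives 200 nM
- compound 2 `CNCC(=O)Nc1cc(OC)ccc1C(=O)c1ccc(OC)c2c1OC(C)(C)C=C2` gives 820 nM
- compound 3 `CNCC(=O)Nc1cc(OC)ccc1C(=O)c1ccc(OC)c2c1C=CC(C)(C)O2` gives 3040 nM

Compound 1 has the lowest number of the three, and its gaps to compound 2 and compound 3 both lie beyond the scatter. The next compound, compound 4 `COc1ccc(C(=O)c2ccc3c(c2)C=CC(C)(C)O3)c(NC(=O)CN(C)C)c1`, keeps the core of compound 1 and has dimethylamino in place of hydroxy on a saturated chain carbon bound to a carbonyl carbon. Within the data shown here, no measured pair isolates this change. Compound 2 (820 nM) and compound 3 (3040 nM) carry methylamino on that chain, but their cores differ from the core of compound 1, so they offer only weak guidance. Both values are higher than that of compound 1 (200 nM), which points to a moderate weakening rather than a gain. The expected size of the change in this assay is the estimated step (a 2.3-fold higher number from compound 1 to compound 4 (0.35 log units; beyond the scatter)). Estimated for compound 4: 450 nM (expected range 120 nM to 1700 nM).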

Compound 4, half-maximal inhibitory concentration: 3560 nM
Beside the measured number, compound 4's estimate is 7.9-fold (0.90 log units) below it; measured number outside the range, above it.
By their numbers in this assay, from the lowest: compound 1; then compound 2; then compounds 3 and 4 (each within the scatter of the next).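

In this assay the change from hydroxy to dimethylamino on a saturated chain carbon bound to a carbonyl carbon gives an 18-fold higher number from compound 1 to compound 4 (1.25 log units; beyond the scatter) on an unchanged core. Among these compounds, this is the only direct reading of the change, and it shows that this position on the core of compound 1 is sensitive: the substituent alone accounts for a large loss. Compound 2 and compound 3 could not show this, as their cores differ from that of compound 1, and no measurement shown accounts for the size of the step.

As far as these compounds go, it remains open whether the loss follows from losing hydroxy or from gaining dimethylamino. Methoxy, an unsubstituted amino group or a longer hydroxyalkyl chain at this place on the core of compound 1 would help separate the two readings.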